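This account rests on a few compounds, and the source may have more. Where it says the series, first, only, none or still open, it means among the compounds named here.

In a functional assay on CCRF-CEM cells (Homo sapiens) for inhibition, read by MTT assay, with a stated time of 72 h (on this read-out lower numbers stand for stronger inhibition and higher numbers for weaker inhibition), compound 1 (`COc1cccc(/C=C/C(=O)Nc2cc(OC)c(OC)c(OC)c2)c1`) gives 23400 nM and compound 2 (`C=C(Br)C(=O)Nc1cccc(/C=C/C(=O)Nc2ccc(F)cc2)c1`) gives 16600 nM so these two values stand within the scatter of each other, and neither compound ranks ahead. Compound 3 (`C=C(Br)C(=O)Nc1cccc(/C=C/C(=O)Nc2ccc(OC(F)(F)F)cc2)c1`) has trifluoromethoxy in place of fluoro on an aromatic carbon para to a large group. Within the data shown here, no step between measured compounds is available as a guide, so in this assay no change beyond the scatter is expected. The expected move is a 1.3-fold lower number from compound 2 to compound 3 (0.11 log units; within the scatter) and no larger. Compound 3 is estimated at 13000 nM (expected range 4500 nM to 35000 nM) for now.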

Compound 3, half-maximal inhibitory concentration: 13000 nM
For compound 3 middle estimate and measured number coincide at the digits printed, within the range that was stated.
By their numbers in this assay, from the lowest: compounds 3, 2 and 1 (each within the scatter of the next).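

In this assay, among these compounds, the first single-place step reads a 1.3-fold lower number from compound 2 to compound 3 (0.11 log units; within the scatter). On this aromatic carbon, para to a large group, going from fluoro to trifluoromethoxy adds heavy atoms and a hydrogen-bond acceptor without moving the number beyond the scatter, so this position tolerates both groups equally within this read-out. No independent data bear on the reason for this. Still open, going by these compounds, is whether an amine or a carboxylic acid at this position would shift the number beyond the scatter. Also open, on these data alone, is how any other part of the shared core responds to change.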